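A Single Amide Change on a Shared Core

A few compounds are considered here, and "the series" means these few. Any claim that something is new, unique, unknown or untested is made for them only; others in the source may bear on it.

This account follows one change made to a shared core, and it has little to lean on. For the measured compounds named here, compound 1 `NC(=O)/C=C/c1ccncc1-c1ccc2ccccc2c1` is the only compound in the group with a number to its name: in a functional assay on HCT-116 cells (Homo sapiens) for inhibition, read by MTT assay, with a stated time of 72 h (a lower number here means a stronger inhibitor of growth, a higher number a weaker inhibitor of growth), compound 1 gives 12100 nM, and it therefore stands alone as the reference point, with nothing to rank it against. Two further compounds belong to the same series but carry no result. In this assay compound 2 `Cn1ccc2cc(-c3cnccc3/C=C/C(=O)N3CCOCC3)ccc21` gives "not determined" (no result reported). Compound 3 `COC1CN(C(=O)/C=C/c2ccncc2-c2ccc(F)cc2)C1` likewise gives "not determined" (no result reported) in this assay.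

Compound 4 `CN(C)C(=O)/C=C/c1ccncc1-c1ccc2ccccc2c1` is the compound still to be measured. It differs from compound 1 in exactly one place: dimethylamino in place of amino on a carbonyl carbon. Going by the values given here, no step between two measured compounds is available, so there is nothing in the data that sets the size of such a change. The expectation is for a small step in this assay, one that stays within the usual scatter, with no clear direction either way.

Compound 4 is therefore expected to give about 15000 nM in this assay, with an estimated range from 4000 nM to 50000 nM. This estimate means an expected step of a 1.2-fold higher number from compound 1 to compound 4 (0.09 log units; within the scatter) that lies within the scatter.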

Compound 4, concentration for 50% growth inhibition: 4540 nM
Beside the measured number, compound 4's estimate is 3.3-fold (0.52 log units) above it; measured number inside the range.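

The pair of compound 1 and compound 4 gives this position its first measured step: in this assay, dimethylamino in place of amino on a carbonyl carbon brings a 2.7-fold lower number from compound 1 to compound 4 (0.43 log units; beyond the scatter) and so moves growth inhibition by a modest amount that still lies beyond the scatter. The earlier compounds shown here could not show this, since compound 1 stood alone with a number and nothing set the size of any change at this carbonyl carbon; the position now proves able to shift the read-out, and on this core the loss of the hydrogen-bond donor counted on amino comes with a lower number, not a higher one. Nothing shown here explains the step.

Compounds 2 and 3 carry no result, so steps to them cannot be read, and this one pair cannot say whether the same change would act alike on any other core. Going by these compounds, whether methylamino or diethylamino on the same carbonyl carbon would take the number further down or bring it back up remains open.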